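Fused triazolothiadiazine series: paw edema inhibition notes

A few compounds are considered here, and "the series" means these few. Any claim that something is new, unique, unknown or untested is made for them only; others in the source may bear on it.

Measured so far in a functional assay on the whole organism (strain Wistar Albino) for inhibition, with Rattus norvegicus as the target, read by paw edema, with a stated time of 2 h, at a dose of 20 mg/kg; a lower number here means less inhibition, a higher number more inhibition at the dose given (going by the name of the read-out):
compound 1 `COc1ccc(Cl)c(-c2nnc3n2NC(c2ccco2)S3)c1` gives 18.7%
compound 2 `COc1ccc(Cc2nnc3n2NC(c2ccco2)S3)cc1OC` gives 17.5%
compound 3 `COc1ccc(Cl)c(-c2nnc3n2NC(c2ccc([N+](=O)[O-])o2)S3)c1` gives 18.5%

Compound 3 sits second highest of the three numbers, yet its nearest neighbour compound 1 and its furthest neighbour compound 2 both lie within the scatter of it, so no order among the three can be read from these values.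

Within the data shown here, the only single-place step measured so far is a number 0.2 percentage points lower from compound 1 to compound 3 (within the scatter), a change on the same saturated ring carbon that compound 4 alters, and it stayed within the scatter.

Compound 4 `COc1ccc(Cl)c(-c2nnc3n2NC(c2ccc[nH]2)S3)c1` carries the change (1H-pyrrol-2-yl in place of 5-nitrofuran-2-yl on a saturated ring carbon). Among the measured compounds shown here, no measured pair exchanges the ring itself at this place; the one step at this position was flat. The expectation for compound 4 in this assay is therefore a step of a number 0.5 percentage points lower from compound 3 to compound 4 (within the scatter), none beyond the scatter.

Compound 4 is estimated at 18%, with a range from 10% to 27%.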

Compound 4, a percentage reported as inhibition, in the whole organism at one dose (the size of the read-out at that dose, not a potency): 15.2%
The estimate for compound 4 lay 2.8 percentage points above the measured number; the measured number falls inside the stated range.
By their numbers in this assay, from the lowest: compounds 4, 2, 3 and 1 (each within the scatter of the next).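

In this assay, among these compounds, the ring itself was exchanged at the saturated ring carbon for the first time, giving a number 3.3 percentage points lower from compound 3 to compound 4 (within the scatter) and, against the unsubstituted furan-2-yl, a number 3.5 percentage points lower from compound 1 to compound 4 (within the scatter) in this series. Furan-2-yl, 5-nitrofuran-2-yl and 1H-pyrrol-2-yl are therefore not told apart at this place by this read-out at this dose, even though the exchange also replaces the ring oxygen with a ring nitrogen bearing a hydrogen-bond donor. No supporting measurement bears on these steps.

Going by these compounds, whether a non-aromatic group at this place, such as a carboxylic acid, an aminomethyl group or a longer alkyl chain, would move the number beyond the scatter remains open. Also open, on these data alone, is whether these three groups stay indistinguishable at other doses or read times.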